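Methoxy isomer swap on the shared core

This account rests on a few compounds, and the source may have more. Where it says the series, first, only, none or still open, it means among the compounds named here.

In a functional assay on MDA-MB-468 cells (Homo sapiens) for cytotoxicity, with a stated time of 48 h (on this read-out higher numbers stand for weaker inhibition and lower numbers for stronger inhibition), compound 2 `COc1ccc(-c2cc(COC(Cc3cn(C4CCN(Cc5ccc([N+](=O)[O-])cc5)CC4)nn3)c3ccc(Br)cc3)on2)cc1` gives 9000 nM. Of the two numbers recorded so far this is the higher, the nearest being compound 1 `O=[N+]([O-])c1ccc(CN2CCC(n3cc(CC(OCc4cc(-c5ccc(Br)cc5)no4)c4ccc(Br)cc4)nn3)CC2)cc1`, which in this assay gives 5000 nM; the gap between the two is within the scatter. For the measured compounds named here, the one measured step, a 1.8-fold higher number from compound 1 to compound 2 (0.26 log units; within the scatter), concerns a different change, so no measured step bears directly on the change now considered. Compound 3 `COc1ccccc1-c1cc(COC(Cc2cn(C3CCN(Cc4ccc([N+](=O)[O-])cc4)CC3)nn2)c2ccc(Br)cc2)on1` differs from compound 2 by 2-methoxyphenyl in place of 4-methoxyphenyl on an aromatic carbon. Going by the values given here, the series holds no measured step of this kind, and the single measured step is within the scatter, so no step beyond the scatter is expected from compound 2 to compound 3, meaning no change at the digits printed from compound 2 to compound 3 (within the scatter). Compound 3 is therefore estimated at 9000 nM, with an expected range from 3000 nM to 27000 nM.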

Compound 3, half-maximal inhibitory concentration: > 25000 nM
Compound 3 gave a limit, no number (the forecaster's own chance of this, stated with the estimate: 10%); middle value at least 2.7-fold (0.44 log units) away from the limit.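

In this assay compound 3 gives a limit and not a number: the limit of > 25000 nM in this assay, at which 1 of the 3 values shown sits. Even so, 2-methoxyphenyl in place of 4-methoxyphenyl gives an at least 2.7-fold higher number from compound 2 to compound 3 (0.44 log units; beyond the scatter), so among the compounds shown, the place of the methoxy on this phenyl ring registers where the exchange of bromo for methoxy, at a 1.8-fold higher number from compound 1 to compound 2 (0.26 log units; within the scatter), did not. Set against the 4-bromophenyl group, 2-methoxyphenyl gives an at least 5.0-fold higher number from compound 1 to compound 3 (0.69 log units; beyond the scatter), so both steps to compound 3 clear the scatter.

From the compounds shown here alone, the full size of both steps stays open, as the limit gives only a bound. Also open, going by these compounds, is whether the shift follows from the methoxy itself or from any group at that place on the phenyl ring, such as an amine or a carboxylic acid.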